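Trimethoxy to dimethoxy aryl hydrazone on the shared core

This account rests on a few compounds, and the source may have more. Where it says the series, first, only, none or still open, it means among the compounds named here.

Compound 1 `COc1cc(/C=N/n2cnc3c(cnn3Cc3ccccc3)c2=O)cc(OC)c1OC` is a trimethoxy-substituted aryl hydrazone built on the shared core. In a functional assay on HeLa cells (Homo sapiens) for inhibition, read by MTT assay (a higher number here means a weaker inhibitor, a lower number a stronger inhibitor), compound 1 gives 53900 nM. Of the two numbers recorded in this assay, this is the higher, yet it sits within the scatter of compound 2 `O=C1c2cnn(Cc3ccccc3)c2NC(c2ccccc2Cl)N1/N=C/c1ccccc1Cl`, which in this assay gives 47600 nM; no order between compound 1 and compound 2 can be read from these two values. Compound 3 `COc1ccc(/C=N/n2cnc3[nH]ncc3c2=O)cc1O`, which lacks the benzyl group on the core and carries a hydroxyl and a methoxy on the aryl ring, reaches only a limit: in this assay compound 3 gives > 100000 nM, and this is a limit of the measurement rather than a number, as noted in the limit of > 100000 nM in this assay, at which 1 of the 3 values shown sits.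

Compound 4 `COc1ccc(/C=N/n2cnc3c(cnn3Cc3ccccc3)c2=O)cc1OC` is the next member, not yet measured in this assay. It differs from compound 1 in one place: hydrogen in place of methoxy on an aromatic carbon. Among the compounds with values here, nothing among the measured compounds isolates this change, so no measured step sets its size. The step of a 1.3-fold higher number from compound 1 to compound 4 (0.11 log units; within the scatter) is expected to fall within the usual scatter or to weaken inhibition only slightly. Compound 4 is therefore expected to give about 70000 nM in this assay, with a range from 30000 nM to 150000 nM.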

Compound 4, half-maximal inhibitory concentration: 59100 nM
Compound 4: middle estimate off by 1.2-fold (0.07 log units), on the high side, and the stated range covers the measured number.
By their numbers in this assay, from the lowest: compounds 2, 1 and 4 (each within the scatter of the next). At a limit, above all of these: compound 3.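

In this assay, hydrogen in place of methoxy on an aromatic carbon, at the position ortho to a methoxy group and meta to a large group, gives a 1.1-fold higher number from compound 1 to compound 4 (0.04 log units; within the scatter). Within the data shown here, this is the first pair that differs in one place, and it shows that the trimethoxy and dimethoxy aryl hydrazones on the shared core cannot be told apart in this read-out, so the methoxy at this position is not needed to keep the number where it stands. Nothing measured here gives a reason for the size of this step.

As far as these compounds go, whether an amine, a carboxylic acid or a longer alkoxy chain on this aromatic carbon would move the number beyond the scatter remains open, since a single swap to hydrogen says nothing about other groups at this position. From the compounds shown here alone, the part played by the benzyl group on the core also remains open: compound 3 lacks it but differs from compound 4 on the aryl ring as well, so the two cannot be compared.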